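The source may hold more compounds than are shown below. What is called first, only, known or untested is meant among the compounds shown, and "the series" means these compounds.

Among the measured compounds shown here, compound 2, `COc1ccc(C(=O)/C(=C/C2CCCCC2)COC(C)=O)cc1`, in a functional assay on NB-4 cells (Homo sapiens) for inhibition, read by XTT assay, with a stated time of 48 h (on this read-out lower numbers stand for stronger inhibition and higher numbers for weaker inhibition), gives 23300 nM, the highest of the two numbers so far; its only neighbour is compound 1, `CCC(/C=C(\COC(C)=O)C(=O)c1ccc(OC)cc1)CC`, which in this assay gives 9500 nM. For the measured compounds named here, the single measured step, a 2.5-fold higher number from compound 1 to compound 2 (0.39 log units; beyond the scatter), concerns a change on a double-bonded chain carbon and does not touch the position altered next. Compound 3, `COc1ccc(C(=O)/C(=C/C2CCCCC2)CCOC(C)=O)cc1`, differs from compound 2 by acetoxymethyl in place of acetoxy on a saturated chain carbon bound to a double-bonded chain carbon; the same difference, cut one bond further out, reads acetoxymethyl to 2-acetoxyethyl. Going by the values given here, no measured step bears on this change, and the two known numbers give no guide to it. For compound 3 the step of a 1.0-fold lower number from compound 2 to compound 3 (0.01 log units; within the scatter) is therefore expected to stay within the scatter, with a wide margin of doubt either way. Compound 3 is estimated to give 23000 nM in this assay, within a range from 8000 nM to 65000 nM.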

Compound 3, half-maximal inhibitory concentration: > 100000 nM
Compound 3: no number, only a limit; the forecaster's own chance of this, stated with the estimate: 10%; at least 4.3-fold (0.63 log units) between middle value and limit.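

In this assay, the value of compound 3, > 100000 nM, is a limit of the assay and not a number. Among the compounds shown here, the position that no earlier step had touched thus proves sensitive: acetoxymethyl in place of acetoxy on a saturated chain carbon bound to a double-bonded chain carbon gives an at least 4.2-fold higher number from compound 2 to compound 3 (0.63 log units; beyond the scatter), although the change only takes the group from 4 to 5 heavy atoms and leaves the counts of hydrogen-bond donors and acceptors as they were. This step can be read only as a minimum, and the one limit among the values shown marks where the scale ends: the limit of > 100000 nM in this assay, at which 1 of the 3 values shown sits.

Going by these compounds, it remains open whether the loss follows from chain length as such or from where the acetate ester sits, which a hydroxymethyl group or a 3-acetoxypropyl chain at this position would help to separate. Also open, on these data alone, is whether the same change would act alike with pentan-3-yl, the group of compound 1, in place of cyclohexyl.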